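From Benzyl Ester to Free Acid at the Shared Core

The source may hold more compounds than are shown below. What is called first, only, known or untested is meant among the compounds shown, and "the series" means these compounds.

Measured compounds:
compound 1 `CCOC(=O)c1c(-c2ccc(OC)c(OC)c2)csc1N(C)C`: 60%
compound 2 `COc1ccc(-c2csc(N)c2C(=O)OCc2cccc(C)c2)cc1OC`: 67%

In an assay on isolated protein for inhibition of protein kinase C zeta type (Homo sapiens), with stated times of 1 h and 2.5 min, tested at 30 uM (a lower number here means less inhibition, a higher number more inhibition at the concentration tested (going by the name of the read-out)), compound 1 gives 60% and compound 2 gives 67%. Compound 2 shows the higher of the two numbers, but its gap to compound 1 lies within the usual scatter, so the two compounds are not distinguished by these results. Within the data shown here, no pair of measured compounds differing in a single place is available, so no measured step guides the next comparison.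

Compound 3 `COc1ccc(-c2csc(N)c2C(=O)O)cc1OC` has not yet been tested. It differs from compound 2 by hydrogen in place of 3-methylbenzyl on an oxygen next to a carbonyl group. Among the measured compounds shown here, nothing among the measured compounds shows what this change does; the expected step of a number 37 percentage points lower from compound 2 to compound 3 (beyond the scatter) is therefore a downward one, larger than the scatter, given only as an estimate. Compound 3 is expected to give 30%, with a range from 5% to 65%.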

Compound 3, a percentage reported as inhibition, at one concentration (the size of the read-out at that concentration, not a potency): 65%
For compound 3 the middle estimate is 35 percentage points below the measured one; the range from low to high includes it.
By their numbers in this assay, from the lowest: compounds 1, 3 and 2 (each within the scatter of the next).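

In this assay the first step measured at this place, hydrogen in place of 3-methylbenzyl on an oxygen next to a carbonyl group, is a number 2 percentage points lower from compound 2 to compound 3 (within the scatter) and so does not separate the two compounds. Losing the 3-methylbenzyl group, with its 8 heavy atoms and its six-membered aromatic ring of carbon only, thus leaves the inhibition at the single tested concentration unchanged within the scatter, which shows that this group is not required for the inhibition seen here. Nothing shown offers an explanation for this outcome.

As far as these compounds go, it remains open whether an amide in place of the free acid, or a longer alkyl chain on this oxygen, would also leave the read-out unchanged. From the compounds shown here alone, because the read-out is not a potency, it is also open whether compound 2 and compound 3 would stay together across a range of concentrations.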